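Moving fluoro and methoxy from compound 3 to compound 4

The compounds below may be only part of what the source reports. "The series", "measured", "known", "first", "only" and "open" are said of these compounds alone.

Measured in an ADME assay on microsomes from liver (Homo sapiens) for metabolic stability, read by LC-MS, with NADPH named in the record, with a stated time of 60 min, tested at 1 uM, in the absence of a further agent; a lower number here means that less of the compound is left, a higher number that more of the compound is left:
- Compound 1 `COc1ccc(-c2c(C)nc3c(N4CC[C@@H](NC(C)=O)C4)cc(C)nn23)cc1OC`: > 95% (a limit)
- Compound 2 `CC(=O)N[C@@H]1CCN(c2cc(C)nn3c(-c4ccc(C#N)cc4)c(C)nc23)C1`: > 95% (a limit)
- Compound 3 `COc1cc(-c2c(C)nc3c(N4CC[C@@H](NC(C)=O)C4)cc(C)nn23)ccc1F`: > 95% (a limit)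

Compound 3 gives > 95% in this assay and this is a limit, not a number. Compound 4 `COc1ccc(-c2c(C)nc3c(N4CC[C@@H](NC(C)=O)C4)cc(C)nn23)cc1F` has the same atoms, joined differently: 3-fluoro-4-methoxyphenyl in place of 4-fluoro-3-methoxyphenyl on an aromatic carbon on an aromatic carbon, with 3-fluoro-4-methoxyphenyl in place of 4-fluoro-3-methoxyphenyl. The measured steps nearest to this change are a step that the two limits leave unreadable from compound 1 to compound 3 and a step that the two limits leave unreadable from compound 2 to compound 3, and the remaining one is a step that the two limits leave unreadable from compound 1 to compound 2, so none of them offers a size to carry over. Compound 3 shares with compound 1 and compound 2 the limit of > 95% in this assay, at which 3 of the 3 values shown sit, and this common ceiling is the only ground for the expectation. In this assay the expected step is a number no higher from compound 3 to compound 4 (the limit leaves the size open) and no direction or size beyond the scatter is expected. For compound 4 the estimate is 95% (expected range 82% to 100%).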

Compound 4, percent of the compound remaining: > 95%
Compound 4 was reported as a limit (the forecaster's own chance of this, stated with the estimate: 65%); the middle value sits exactly at the limit.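

No step from compound 1, compound 2 or compound 3 to compound 4 can be read, as all four stand at one shared ceiling: the limit of > 95% in this assay, at which 4 of the 4 values shown sit.

Whether 3-fluoro-4-methoxyphenyl in place of 4-fluoro-3-methoxyphenyl, or any other change among these compounds, alters the compound remaining stays open.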